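Adding an Amino Group to Compound 3

The compounds below may be only part of what the source reports. "The series", "measured", "known", "first", "only" and "open" are said of these compounds alone.

Compound 3 `CCCOc1cc(C(=O)Nc2nn[nH]n2)nc(-c2ccccc2)c1` gives 100% in a functional assay on the whole organism with Rattus norvegicus as the target, at a dose of 3 mg/kg by the oral route; on this read-out lower numbers stand for a weaker effect and higher numbers for a stronger effect at the one dose given. Compound 1 `Nc1ccc(-c2cc(Cl)cc(C(=O)Nc3nn[nH]n3)n2)cc1` gives 100%, so compound 3 stands level with compound 1, the two together being the highest of three numbers and within the scatter of each other. Compound 2 `CCOc1cc(C(=O)Nc2nn[nH]n2)nc(-c2ccc(N)cc2)c1` gives 62%, the number furthest from compound 3. Among the measured compounds shown here, the one measured step, a number 38 percentage points lower from compound 1 to compound 2 (beyond the scatter), concerns ethoxy in place of chloro and leaves the amino group untouched, so no measured step bears directly on the change leading to compound 4 `CCCOc1cc(C(=O)Nc2nn[nH]n2)nc(-c2ccc(N)cc2)c1`, which is amino in place of hydrogen on an aromatic carbon. Compound 1 and compound 2 both carry an amino group and between them span the whole range seen. Compound 4 is therefore expected near 85%, with a range from 55% to 100%. This estimate means a number 15 percentage points lower from compound 3 to compound 4 (beyond the scatter).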

Compound 4, a percentage reported as inhibition, in the whole organism at one dose (the size of the read-out at that dose, not a potency): 68%
Beside the measured number, compound 4's estimate is 17 percentage points above it, and the stated range covers the measured number.
By their numbers in this assay, from the lowest: compounds 2 and 4 (each within the scatter of the next); then compounds 1 and 3 (each within the scatter of the next).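

In this assay, among the compounds shown here, the change from phenyl to 4-aminophenyl gives the first direct reading of this position, and it is a large loss (a number 32 percentage points lower from compound 3 to compound 4 (beyond the scatter)). With the amino group present, propoxy and ethoxy cannot be told apart (a number 6 percentage points higher from compound 2 to compound 4 (within the scatter)), while chloro stands clearly apart from propoxy (a number 32 percentage points lower from compound 1 to compound 4 (beyond the scatter)). Nothing measured here gives a reason for the loss. Open, going by these compounds, is whether a hydroxyl or methoxy group in place of the amino group would give a similar loss, and whether a shorter or longer alkoxy chain would matter.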